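Swapping 2-chlorophenyl for 4-methylphenyl on a saturated ring carbon

This account rests on a few compounds, and the source may have more. Where it says the series, first, only, none or still open, it means among the compounds named here.

Within the data shown here, in an ADME assay on Vero 76 cells (Chlorocebus sabaeus) for cytotoxicity, read by MTT assay, with a stated time of 96 h (on this read-out lower numbers stand for higher toxicity in this test and higher numbers for lower toxicity in this test), compound 3 `NS(=O)(=O)c1ccc(N2N=C(c3ccc(OCc4ccccc4)cc3)CC2c2ccccc2Cl)cc1` gives 92000 nM, the higher of the two exact numbers so far. Compound 1 `Cc1ccc(C2CC(c3ccccc3)=NN2c2ccc(S(N)(=O)=O)cc2)cc1` gives 20000 nM. Compound 2 `NS(=O)(=O)c1ccc(N2N=C(c3ccc(OCc4ccccc4)cc3)CC2c2ccccc2)cc1` gives > 100000 nM, which is a limit of the assay and not a number. Compound 4 `Cc1ccc(C2CC(c3ccc(OCc4ccccc4)cc3)=NN2c2ccc(S(N)(=O)=O)cc2)cc1` has not yet been measured; it carries 4-methylphenyl in place of 2-chlorophenyl on a saturated ring carbon. Among the measured compounds shown here, the only measured step that touches this group is chloro in place of hydrogen on an aromatic carbon, an at least 1.0-fold lower number from compound 2 to compound 3 (0.03 log units; that floor lies within the scatter), and it shows no clear change. Compound 1 carries the same 4-methylphenyl and its 20000 nM is a lower number, but it lacks the benzyloxy group of compound 3, so it is only a loose guide. A modest move towards a lower number is therefore expected, and the estimated step is a 1.5-fold lower number from compound 3 to compound 4 (0.19 log units; within the scatter). For compound 4 the estimated value is 60000 nM, with an expected range of 25000 nM to 100000 nM.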

Compound 4, half-maximal cytotoxic concentration: 100000 nM
Beside the measured number, compound 4's estimate is 1.7-fold (0.22 log units) below it; measured number inside the range.
By their numbers in this assay, from the lowest: compound 1; then compounds 3 and 4 (each within the scatter of the next).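

In this assay, the exchange of 2-chlorophenyl for 4-methylphenyl on the saturated ring carbon gives a 1.1-fold higher number from compound 3 to compound 4 (0.04 log units; within the scatter), so these two groups cannot be told apart at this position. The benzyloxy group makes the clearer difference: with 4-methylphenyl held in place, adding the benzyloxy group gives a 5.0-fold higher number from compound 1 to compound 4 (0.70 log units; beyond the scatter), and a higher number here stands for lower toxicity in this test. The remaining step gives a number no higher from compound 2 to compound 4 (the limit leaves the size open) and its size cannot be read. Compound 2 carries a limit of the assay and not a number: the limit of > 100000 nM in this assay, at which 1 of the 4 values shown sits.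

Going by these compounds, the benzyloxy step rests on a single pair of compounds, and it remains open whether it would hold with 2-chlorophenyl on the saturated ring carbon. Also open, on these data alone, is how an amine or a carboxylic acid on that aromatic ring would change the number.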